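This account rests on a few compounds, and the source may have more. Where it says the series, first, only, none or still open, it means among the compounds named here.

In an ADME assay on microsomes from liver (Homo sapiens) for metabolic stability (on this read-out lower numbers stand for slow clearance and higher numbers for fast clearance), compound 3 (`Cc1ccc(C(=O)Nc2cn3ncnc3c(CN3CCN(C(=O)C4CCOCC4)[C@@H](C)C3)c2C)cn1`) reads < 10 mL.min-1.g-1, which is a limit and not a number. Compound 2 (`Cc1ccc(C(=O)Nc2cn3ncnc3c(CN3CCN(C(=O)CCC(F)(F)F)[C@@H](C)C3)c2C)cn1`) reads < 10 mL.min-1.g-1, also a limit. Compound 1 (`Cc1ccc(C(=O)Nc2cn3ncnc3c(CN3CCN(C(=O)C(C)C)[C@@H](C)C3)c2C)cn1`) gives 240 mL.min-1.g-1. Within the data shown here, two measured steps bear on what follows, both large: an at least 24-fold lower number from compound 1 to compound 2 (1.38 log units; beyond the scatter) and an at least 24-fold lower number from compound 1 to compound 3 (1.38 log units; beyond the scatter).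

Compound 4 (`Cc1ccc(C(=O)Nc2cn3ncnc3c(CN3CCN(C(=O)CC(C)C)[C@@H](C)C3)c2C)cn1`) carries isobutyl in place of oxan-4-yl on a carbonyl carbon. The nearest measured group is the isopropyl of compound 1, at 240 mL.min-1.g-1, so a large move to a higher number is expected in this assay. Compound 2 goes against any simple reading and keeps the range wide. The expected size is an at least 10-fold higher number from compound 3 to compound 4 (1.00 log units; beyond the scatter). For compound 4 the estimated value is 100 mL.min-1.g-1, with an expected range from 25 mL.min-1.g-1 to 300 mL.min-1.g-1.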

Compound 4, intrinsic clearance in microsomes: 20 mL.min-1.g-1
Compound 4: the middle estimate sits 5.0-fold (0.70 log units) above what was measured; the measured number lies below the stated range.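

In this assay, isobutyl in place of isopropyl on this carbonyl carbon gives a 12-fold lower number from compound 1 to compound 4 (1.08 log units; beyond the scatter) and shows that a large step here needs neither the oxan-4-yl ring nor fluorine. Against the other two compounds the steps read an at least 2.0-fold higher number from compound 3 to compound 4 (0.30 log units; that floor lies within the scatter) and an at least 2.0-fold higher number from compound 2 to compound 4 (0.30 log units; that floor lies within the scatter) and neither floor goes beyond the scatter. The full size of both steps stays unread, each resting on a limit and not a number: the limit of < 10 mL.min-1.g-1 in this assay, at which 2 of the 4 values shown sit. From the compounds shown here alone, whether an amine or a carboxylic acid on this carbonyl carbon, or a longer chain, would stay near compound 4 remains open.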